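The compounds below may be only part of what the source reports. "The series", "measured", "known", "first", "only" and "open" are said of these compounds alone.

Values in a functional assay on HepG2 cells (Homo sapiens) for cytotoxicity, read by MTT assay, with a stated time of 72 h (a higher number here means a weaker inhibitor, a lower number a stronger inhibitor), so far:
compound 1 `CNC(=O)c1cc(Oc2ccc(C(=O)/C=C/c3cccc(Br)c3)cc2)ccn1` gives 2870 nM
compound 2 `CNC(=O)c1cc(Oc2ccc(C(=O)/C=C/c3ccc(C#N)cc3)cc2)ccn1` gives 5430 nM
compound 3 `CNC(=O)c1cc(Oc2ccc(C(=O)/C=C/c3ccc(F)cc3)cc2)ccn1` gives 12600 nM

Compound 3 has the highest number of the three at 12600 nM in this assay and sits closest to compound 2, with a 2.3-fold higher number from compound 2 to compound 3 (0.37 log units; beyond the scatter) as the gap.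

Next is compound 4 `CNC(=O)c1cc(Oc2ccc(C(=O)/C=C/c3cccc(Cl)c3Cl)cc2)ccn1`, which differs from compound 3 as follows: 2,3-dichlorophenyl in place of 4-fluorophenyl on a double-bonded chain carbon bound to a double-bonded chain carbon.

Within the data shown here, no measured compound carries 2,3-dichlorophenyl, so the evidence is indirect. The most relevant comparison is a 4.4-fold higher number from compound 1 to compound 3 (0.64 log units; beyond the scatter), which, read in reverse, puts the 3-bromophenyl of compound 1 lower than the 4-fluorophenyl of compound 3. The other step, a 1.9-fold higher number from compound 1 to compound 2 (0.28 log units; within the scatter), does not separate those two compounds. A modest move to a lower number is therefore expected, roughly as large as the gap to compound 1 or smaller.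

The expected step is a 2.8-fold lower number from compound 3 to compound 4 (0.45 log units; beyond the scatter) in this assay.

For compound 4 the estimated value is 4500 nM, with an expected range of 1800 nM to 11000 nM.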

Compound 4, half-maximal inhibitory concentration: > 50000 nM
Compound 4 was reported as a limit; the forecaster's own chance of this, stated with the estimate: 3%; at least 11-fold (1.04 log units) between middle value and limit.
By their numbers in this assay, from the lowest: compounds 1 and 2 (each within the scatter of the next); then compound 3. At a limit, above all of these: compound 4.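

In this assay compound 4 is reported only as a limit: the limit of > 50000 nM in this assay, at which 1 of the 4 values shown sits.

Among these compounds, with an at least 3.9-fold higher number from compound 3 to compound 4 (0.59 log units; beyond the scatter) and an at least 9.2-fold higher number from compound 2 to compound 4 (0.96 log units; beyond the scatter) and an at least 17-fold higher number from compound 1 to compound 4 (1.24 log units; beyond the scatter) as the new steps, 2,3-dichlorophenyl is the first group on this double-bonded chain carbon to reach the limit, and all three steps are beyond the scatter. Halogen on this ring does not by itself keep the number low, as 3-bromophenyl in compound 1 and 4-fluorophenyl in compound 3 also carry halogen and both give measured values.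

The limit leaves the full size of all three steps unknown, and the compounds shown do not separate the effect of two chlorines from that of a single chlorine on this ring. On these data alone, how an amine or a carboxylic acid on this ring would read in this assay also remains open.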